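Cytotoxicity notes on an amide series with a shared core

The source may hold more compounds than are shown below. What is called first, only, known or untested is meant among the compounds shown, and "the series" means these compounds.

Measured so far:
- Compound 1 `Cc1ccc(NC(=O)c2ccc(F)cc2)cc1-n1cc(-c2cnc3cccnn23)cn1` in an ADME assay on HEK-293T cells (Homo sapiens) for cytotoxicity, read by CCK-8 assay, with a stated time of 24 h; on this read-out higher numbers stand for lower toxicity in this test and lower numbers for higher toxicity in this test: > 80000 nM, a limit of the test.
- Compound 2 `Cc1ccc(NC(=O)c2cccc(Cl)c2)cc1-n1cc(-c2cnc3cccnn23)cn1` in this assay : > 80000 nM, again a limit of the test.

Compound 2 stands at the limit of this assay and nothing more can be read from its number. Among the compounds with values here, the one measured step, a step that the two limits leave unreadable from compound 1 to compound 2, is left unreadable by the two limits, so it says nothing about how the aryl group on the carbonyl carbon affects the read-out. What the data show is only (the limit of > 80000 nM in this assay, at which 2 of the 2 values shown sit).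

Compound 3 `CCc1ccc(C(=O)Nc2ccc(C)c(-n3cc(-c4cnc5cccnn45)cn3)c2)cc1` differs from compound 2 by 4-ethylphenyl in place of 3-chlorophenyl on a carbonyl carbon. Within the data shown here, no measured step bears on this change in a readable way; the sole neighbouring step ended at the limit on both sides. The expectation for compound 3 therefore rests on both measured compounds sitting at the limit: compound 3 is expected to give 80000 nM, with a range from 40000 nM to 200000 nM. The expected step is a number no higher from compound 2 to compound 3 (the limit leaves the size open), nothing beyond the scatter, and most likely another limit.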

Compound 3, half-maximal cytotoxic concentration: > 80000 nM
Compound 3: no number, only a limit; the forecaster's own chance of this, stated with the estimate: 85%; the middle value lies on the limit itself.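

Within the data shown here, no step among compound 1, compound 2 and compound 3 can be read, since all three sit at the same limit of the test: the limit of > 80000 nM in this assay, at which 3 of the 3 values shown sit. The compounds shown leave open where any of them would give an actual number in this assay, and whether the aryl group on the carbonyl carbon changes that number at all.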